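Ethoxycarbonyl in place of hydroxymethyl: working notes

The compounds below may be only part of what the source reports. "The series", "measured", "known", "first", "only" and "open" are said of these compounds alone.

Measured in a functional assay on HeLa cells (Homo sapiens) for cytotoxicity, read by MTT assay, with a stated time of 48 h; a higher number here means a weaker inhibitor, a lower number a stronger inhibitor
- compound 1 `CCOC(=O)C1(C(=O)Nc2ccccc2Cl)CC1c1cc(OC)c(OC)c(OC)c1` gives 22100 nM; 76400 nM (2 entries)
- compound 2 `CCOC(=O)[C@@]1(C(=O)Nc2ccccc2Cl)C[C@@H]1c1cc(OC)c(OC)c(OC)c1` gives > 100000 nM (a limit, not a number)
- compound 3 `COc1cc([C@H]2C[C@]2(CO)C(=O)Nc2ccccc2Cl)cc(OC)c1OC` gives 45500 nM

Within the data shown here, compound 3 holds the only single number in this set (45500 nM), so it serves as the reference point. Compound 4 `CCOC(=O)[C@]1(C(=O)Nc2ccccc2Cl)C[C@@H]1c1cc(OC)c(OC)c(OC)c1`, not yet measured, carries ethoxycarbonyl in place of hydroxymethyl on a saturated ring carbon. Among the measured compounds shown here, no measured step bears directly on this change. Compound 1, which also carries ethoxycarbonyl, gives 22100 nM; 76400 nM (2 entries), and these entries span the value of compound 3, so no change beyond the scatter is expected in this assay. The expected size is a 1.1-fold higher number from compound 3 to compound 4 (0.04 log units; within the scatter). For compound 4 the estimated value is 50000 nM, with an expected range of 18000 nM to 130000 nM.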

Compound 4, half-maximal inhibitory concentration: > 100000 nM
Compound 4: a limit, no number; the forecaster's own chance of this, stated with the estimate: 30%; at least 2.0-fold (0.30 log units) between middle value and limit.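

In this assay, ethoxycarbonyl in place of hydroxymethyl on a saturated ring carbon gives an at least 2.1-fold higher number from compound 3 to compound 4 (0.34 log units; beyond the scatter). Among these compounds, this is the only readable step at this position, and its direction gives hydroxymethyl the lower number. Compound 2 and compound 4 both stand at a limit of the assay, not at a number, so the step between these two configurations cannot be read: the limit of > 100000 nM in this assay, at which 2 of the 4 values shown sit.

From the compounds shown here alone, it remains open how a carboxylic acid or an aminomethyl group at this position would read in this assay. Going by these compounds, it also remains open whether configuration at this carbon matters with hydroxymethyl in place.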